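A Hydroxymethyl Substituent on a Weakly Cytotoxic Scaffold

This account rests on a few compounds, and the source may have more. Where it says the series, first, only, none or still open, it means among the compounds named here.

Compound 1 `OC1CNCc2nc(-c3ccc(N4CCCC4)cc3)sc21` is one of two compounds tested in a functional assay on MCF-10A cells (Homo sapiens) for cytotoxicity, read by sulforhodamine B assay, with a stated time of 2 days; a lower number here means a stronger inhibitor, a higher number a weaker inhibitor; there compound 1 gives 27800 nM, the only numerical result shown. Compound 2 `Cc1cc(N(C)C)ccc1-c1nc2c(s1)[C@H](O)CCC2` reaches only a limit of the assay, > 100000 nM, in this assay. Among the compounds with values here, compound 1 thus stands as the sole measured number, beside (the limit of > 100000 nM in this assay, at which 1 of the 2 values shown sits). Compound 3 `OCc1cc(N2CCCC2)ccc1-c1nc2c(s1)C(O)CNC2` differs from compound 1 by hydroxymethyl in place of hydrogen on an aromatic carbon. Within the data shown here, no measured pair shows this change, so the expected step in this assay is small and of uncertain direction, a 1.3-fold higher number from compound 1 to compound 3 (0.10 log units; within the scatter). Compound 3 is therefore estimated to give about 35000 nM, between 10000 nM and 100000 nM.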

Compound 3, half-maximal inhibitory concentration: > 100000 nM
Compound 3 ended at the assay's limit (the forecaster's own chance of this, stated with the estimate: 25%); middle value at least 2.8-fold (0.45 log units) away from the limit.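

In this assay, hydroxymethyl in place of hydrogen on an aromatic carbon, ortho to a large group and meta to a pyrrolidin-1-yl group, gives an at least 3.5-fold higher number from compound 1 to compound 3 (0.55 log units; beyond the scatter), the first measured sign that a change at this position can move the number beyond the scatter. Compound 3 gives > 100000 nM, which is a limit of the assay. Only compound 1 now keeps a numerical result: the limit of > 100000 nM in this assay, at which 2 of the 3 values shown sit.

The compounds shown leave open how far the step extends past this limit. They also leave open whether methyl, an aminomethyl group or a carboxylic acid at this position would give a numerical result.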